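Changing the Amide Nitrogen Substituent of Compound 1

The source may hold more compounds than are shown below. What is called first, only, known or untested is meant among the compounds shown, and "the series" means these compounds.

compound 1 `CCOC(=O)C1=C(C)NC(C)=C(C(=O)OCC)C1c1ccc(OCC(=O)NCc2ccccc2)cc1`: 8.33%
compound 2 `CCOC(=O)C1=C(C)NC(C)=C(C(=O)OCC)C1c1ccc(OCC(=O)Nc2ccc(C)cc2)cc1`: 43.9%
compound 3 `CCOC(=O)C1=C(C)NC(C)=C(C(=O)OCC)C1c1ccc(OCC(=O)Nc2nc3ccccc3s2)cc1`: 47.7%

In a functional assay on the whole organism (strain Wistar) for inhibition, with Rattus norvegicus as the target, read by paw edema, with stated times of 30 min and 0.5 h, at a dose of 20 mg/kg (on this read-out lower numbers stand for less inhibition and higher numbers for more inhibition at the one dose given (going by the name of the read-out)), compound 1 gives 8.33%, the lowest of the three numbers, while compound 2 gives 43.9% and compound 3 gives 47.7%. Compound 4 `CCOC(=O)C1=C(C)NC(C)=C(C(=O)OCC)C1c1ccc(OCC(=O)NNC(=O)c2ccc(C)cc2)cc1` differs from compound 1 in one place: ((4-methylphenyl)carbonyl)amino in place of benzyl on an amide-type nitrogen. Among the measured compounds shown here, the steps that bear on this change are a number 35.6 percentage points higher from compound 1 to compound 2 (beyond the scatter) and a number 39.4 percentage points higher from compound 1 to compound 3 (beyond the scatter), both large, whereas a number 3.8 percentage points higher from compound 2 to compound 3 (within the scatter). For the measured compounds named here, compound 4 carries the 4-methylphenyl of compound 2, yet joined to the amide nitrogen through a carbonyl and a further nitrogen, and no measured step covers that arrangement. Compound 4 is therefore expected to rise above compound 1 by a number 21.7 percentage points higher from compound 1 to compound 4 (beyond the scatter), with wide uncertainty. The estimate for compound 4 is 30%, between 10% and 50%.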

Compound 4, a percentage reported as inhibition, in the whole organism at one dose (the size of the read-out at that dose, not a potency): 16.7%
Beside the measured number, compound 4's estimate is 13.3 percentage points above it, and the stated range covers the measured number.
By their numbers in this assay, from the lowest: compounds 1 and 4 (each within the scatter of the next); then compounds 2 and 3 (each within the scatter of the next).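

In this assay ((4-methylphenyl)carbonyl)amino on the amide-type nitrogen does not stand apart from benzyl, with a number 8.4 percentage points higher from compound 1 to compound 4 (within the scatter) on that change. The same group gives up most of what the other two substituents gained, with a number 27.2 percentage points lower from compound 2 to compound 4 (beyond the scatter) and a number 31 percentage points lower from compound 3 to compound 4 (beyond the scatter) against them. The 4-methylphenyl ring alone therefore does not secure a high number at this position, since its presence in ((4-methylphenyl)carbonyl)amino does not reproduce the result of compound 2.

Going by these compounds, whether plain phenyl or cyclohexyl on this nitrogen would hold the higher numbers remains open. No measurement shown explains these differences.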